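Sulfonyl aryl replacements in a factor X sulfonamide series

A few compounds are considered here, and "the series" means these few. Any claim that something is new, unique, unknown or untested is made for them only; others in the source may bear on it.

Measured so far in an assay on isolated protein for inhibition of coagulation factor X (Oryctolagus cuniculus), tested at 1 uM; on this read-out higher numbers stand for more inhibition at the one concentration tested (going by the name of the read-out) and lower numbers for less inhibition:
compound 1 `O=C1[C@@H](NS(=O)(=O)c2cc3ccc(Cl)nc3s2)CCN1Cc1cc2cc[nH]cc-2n1`: 50%
compound 2 `CC(C)(C)c1ccc(S(=O)(=O)N[C@H]2CCN(Cc3cc4cc[nH]cc-4n3)C2=O)cc1`: 57%

In this assay compound 2 gives 57%, and the step of a number 7 percentage points higher from compound 1 to compound 2 (within the scatter) lies within the scatter, so compound 1 and compound 2 are not told apart by these numbers. Compound 3 `O=C1[C@@H](NS(=O)(=O)c2nc3cc(Cl)ccc3[nH]2)CCN1Cc1cc2cc[nH]cc-2n1` carries 5-chloro-1H-benzimidazol-2-yl in place of 4-(tert-butyl)phenyl on a sulfonyl sulfur. Among the compounds with values here, the only step that bears on this is the earlier exchange on the same sulfonyl sulfur, from compound 1 to compound 2, which stayed within the scatter. On that basis the step of a number 7 percentage points lower from compound 2 to compound 3 (within the scatter) is expected to stay within the scatter as well. For compound 3 the estimate in this assay is 50%, with a range from 25% to 75%.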

Compound 3, a percentage reported as inhibition, at one concentration (the size of the read-out at that concentration, not a potency): 21%
Beside the measured number, compound 3's estimate is 29 percentage points above it; the measured number lies below the stated range.
By their numbers in this assay, from the lowest: compound 3; then compounds 1 and 2 (each within the scatter of the next).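

Unlike the earlier exchange at this position, this one separates compounds in this assay: 5-chloro-1H-benzimidazol-2-yl in place of 4-(tert-butyl)phenyl gives a number 36 percentage points lower from compound 2 to compound 3 (beyond the scatter) and the same group also falls short of the group in compound 1, with a number 29 percentage points lower from compound 1 to compound 3 (beyond the scatter) as the printed step. The group on the sulfonyl sulfur can therefore move this read-out beyond the scatter. No available measurement accounts for the difference.

Still open, on these data alone, is whether the hydrogen-bond donor counted in the entering group matters. A 5-chloroindol-2-yl or 5-chloro-1-methyl-1H-benzimidazol-2-yl group on the same sulfonyl sulfur would bear on that.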